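Ester variation on the compound 3 core: working notes

A few compounds are considered here, and "the series" means these few. Any claim that something is new, unique, unknown or untested is made for them only; others in the source may bear on it.

Measured so far:
compound 1 `COC(=O)c1ccc2c(C=O)cc(-c3ccccc3)c-2cc1`: 1.8%
compound 2 `Cc1ccc2ccc(C(=O)c3ccc(C(F)(F)F)cc3)c-2cc1`: 31%
compound 3 `O=C(Oc1ccc2ccc(Cl)ccc1-2)c1ccccc1`: 34.3%

In an assay on cells for displacement of a labelled ligand from Orexin receptor type 2 (Homo sapiens), read by scintillation counting, with stated times of 10 min and 90 min, tested at 10 uM (on this read-out higher numbers stand for more inhibition at the one concentration tested (going by the name of the read-out) and lower numbers for less inhibition), compound 3 gives 34.3%, the highest of the three numbers. Compound 2 sits within the scatter of compound 3, so no order between them is claimed; compound 1 lies beyond the scatter, well below. Compound 4 `COC(=O)CCC(=O)Oc1ccc2ccc(Cl)ccc1-2` differs from compound 3 in one place: 2-(methoxycarbonyl)ethyl in place of phenyl on a carbonyl carbon. Going by the values given here, no step between two measured compounds isolates this change, and the three values shown leave the weight of the phenyl on the carbonyl carbon unresolved. A modest downward step is expected in this assay, possibly not beyond the scatter. The step of a number 14.3 percentage points lower from compound 3 to compound 4 (beyond the scatter) expresses this expectation. Compound 4 is estimated at 20%, with a range from 0% to 45%.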

Compound 4, a percentage reported as inhibition, at one concentration (the size of the read-out at that concentration, not a potency): 24.3%
Beside the measured number, compound 4's estimate is 4.3 percentage points below it, within the range that was stated.
By their numbers in this assay, from the lowest: compound 1; then compounds 4, 2 and 3 (each within the scatter of the next).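

In this assay, going by these compounds alone, 2-(methoxycarbonyl)ethyl in place of phenyl on a carbonyl carbon gives a number 10 percentage points lower from compound 3 to compound 4 (within the scatter), the first reading of this position. The aromatic ring of phenyl is thus not required here for a value within the scatter of compound 3, and a chain with no ring serves equally on this reading. Nothing measured on these compounds explains this result.

Open, from the compounds shown here alone, is whether a carboxylic acid, an amine or a longer chain in place of 2-(methoxycarbonyl)ethyl stays within the scatter of compound 4. Within the data shown here, a single concentration also gives no potency for either compound.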